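Furan-2-yl in place of phenyl on the fused lactam ring

A few compounds are considered here, and "the series" means these few. Any claim that something is new, unique, unknown or untested is made for them only; others in the source may bear on it.

Measured compounds:
compound 1 `Nc1sc(-c2ccc(F)cc2)c(-c2ccc(Cl)cc2)c1C(=O)NC1CC1`, 28000 nM
compound 2 `O=C1CC(c2ccccc2)c2c(sc(-c3ccc(Cl)cc3)c2-c2ccc(Cl)cc2)N1`, > 50000 nM

Compound 1 gives 28000 nM in a functional assay on PC-3 cells (Homo sapiens) for cytotoxicity, read by sulforhodamine B assay, with a stated time of 72 h; a lower number here means a stronger inhibitor, a higher number a weaker inhibitor. Compound 2 reaches only the limit of this assay, > 50000 nM, so no number is known for it. Of the two values shown, one sits at that limit (the limit of > 50000 nM in this assay, at which 1 of the 2 values shown sits), and compound 2 is the one; it stands at the weak end of what this series has shown so far.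

Compound 3 `O=C1CC(c2ccco2)c2c(sc(-c3ccc(Cl)cc3)c2-c2ccc(Cl)cc2)N1` differs from compound 2 by furan-2-yl in place of phenyl on a saturated ring carbon. Going by the values given here, no measured pair makes this kind of change, so the size of the step is open. With compound 2 at the limit, the expectation for this assay is a step of no more than the usual scatter, in no preferred direction, and the estimate for compound 3 is 60000 nM, within 20000 nM to 200000 nM. The step this expectation means from compound 2 to compound 3 is estimated as a step that the limit leaves unreadable from compound 2 to compound 3.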

Compound 3, half-maximal inhibitory concentration: > 50000 nM
Compound 3 ended at the assay's limit (the forecaster's own chance of this, stated with the estimate: 70%); the middle value is on the limit's open side.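

Compound 2 and compound 3 are both limits rather than numbers in this assay, so no step between them can be read: the limit of > 50000 nM in this assay, at which 2 of the 3 values shown sit.

Left open is whether any group on that saturated ring carbon gives a number in this assay and how far furan-2-yl and phenyl truly differ there.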